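A few compounds are considered here, and "the series" means these few. Any claim that something is new, unique, unknown or untested is made for them only; others in the source may bear on it.

In a functional assay on K562 cells (Homo sapiens), read by MTT assay, with a stated time of 72 h (on this read-out higher numbers stand for weaker inhibition and lower numbers for stronger inhibition), the measured compounds are:
compound 1 `C#Cc1cn([C@@H]2O[C@H](CO)[C@@H](O)[C@H]2O)c2ncnc(N(C)C)c12`: 260 nM
compound 2 `Cc1ncnc2c1c(-c1ccsc1)cn2[C@@H]1O[C@H](CO)[C@@H](O)[C@H]1O`: 5550 nM
compound 3 `Cc1ncnc2c1c(-c1cc3ccccc3o1)cn2[C@@H]1O[C@H](CO)[C@@H](O)[C@H]1O`: > 20000 nM (a limit)

Compound 3 gives no number, only (the limit of > 20000 nM in this assay, at which 1 of the 3 values shown sits). Compound 4 `C#Cc1cn([C@@H]2O[C@H](CO)[C@@H](O)[C@H]2O)c2ncnc(C)c12` carries ethynyl in place of 1-benzofuran-2-yl on an aromatic carbon. For the measured compounds named here, one measured step touches this carbon: an at least 3.6-fold higher number from compound 2 to compound 3 (0.55 log units; beyond the scatter), with 1-benzofuran-2-yl entering in place of thiophen-3-yl. Taking 1-benzofuran-2-yl away should therefore move the number the other way. Compound 1 also bears ethynyl, with a different group elsewhere on the core, and gives 260 nM. A large drop in this assay is expected, the estimated step being an at least 40-fold lower number from compound 3 to compound 4 (1.60 log units; beyond the scatter). For compound 4 the expected value is 500 nM, with an estimated range of 80 nM to 3500 nM.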

Compound 4, half-maximal inhibitory concentration: 110 nM
Beside the measured number, compound 4's estimate is 4.5-fold (0.66 log units) above it; low and high end bracket the measured number.
By their numbers in this assay, from the lowest: compound 4; then compound 1; then compound 2. At a limit, above all of these: compound 3.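

In this assay, ethynyl on this aromatic carbon gives a 50-fold lower number from compound 2 to compound 4 (1.70 log units; beyond the scatter), so here a two-carbon group without a ring far outdoes thiophen-3-yl. The step of an at least 180-fold lower number from compound 3 to compound 4 (2.25 log units; beyond the scatter) is only a bound, since compound 3 gives a limit: the limit of > 20000 nM in this assay, at which 1 of the 4 values shown sits. With ethynyl kept, methyl in place of dimethylamino on an aromatic carbon gives a 2.4-fold lower number from compound 1 to compound 4 (0.37 log units; beyond the scatter), much smaller than the steps at the ethynyl carbon.

The compounds shown leave open whether a longer chain ending in a triple bond, or an amine, would fare as well as ethynyl on this carbon.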